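The source may report more compounds than this note shows. Statements on the series, on what has been measured and on what is new or still open speak of the compounds shown alone.

Measured in a physicochemical assay for solubility; a higher number here means a more soluble compound, a lower number a less soluble compound:

- Compound 1 `CCS(=O)(=O)c1ccc2c(c1)C(C)=CN(C)C(=O)[C@@H]2C`: >= 131 ug/mL
- Compound 2 `CCS(=O)(=O)c1ccc2c(c1)C(C(N)=O)=CN(C)C(=O)[C@@H]2C`: 82 ug/mL
- Compound 3 `CCS(=O)(=O)c1ccc2c(c1)C(c1cnn(C)c1)=CN(C)C(=O)[C@@H]2C`: >= 222 ug/mL

The entry for compound 1 is a limit of the assay, not a number. Compound 3 stands at >= 222 ug/mL, which is also a limit. The three measured steps all change the group on a double-bonded ring carbon. They show an at least 1.5-fold lower number from compound 1 to compound 2 (0.20 log units; that floor lies within the scatter), an at least 2.7-fold higher number from compound 2 to compound 3 (0.43 log units; beyond the scatter) and a step that the two limits leave unreadable from compound 1 to compound 3.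

Compound 4 `C[C@H]1C(=O)N(C)C=C(c2cnn(C)c2)c2cc(C(CO)CO)ccc21` keeps the 1-methyl-1H-pyrazol-4-yl group of compound 3 and differs elsewhere, with 2-hydroxy-1-(hydroxymethyl)ethyl in place of ethylsulfonyl on an aromatic carbon. Among the compounds with values here, none of the measured steps touches this place, and none gives a size for the change. No step beyond the scatter is therefore expected in this assay, in either direction, and the expected step is a number no higher from compound 3 to compound 4 (the limit leaves the size open). Compound 4 is estimated at 220 ug/mL. The expected range for compound 4 runs from 90 ug/mL to 450 ug/mL.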

Compound 4, solubility: >= 208 ug/mL
Compound 4 gave a limit, no number; the forecaster's own chance of this, stated with the estimate: 45%; the middle value lies beyond the limit too.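

Within the data shown here, compound 3 and compound 4 both stand as limits of the assay, not numbers, and no step between them can be read in this assay. The compounds shown leave open whether 2-hydroxy-1-(hydroxymethyl)ethyl in place of ethylsulfonyl on an aromatic carbon changes the read-out, in either direction.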